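Fixing One Stereocentre in a Calcium-Flux Antagonist Series

A few compounds are considered here, and "the series" means these few. Any claim that something is new, unique, unknown or untested is made for them only; others in the source may bear on it.

Compound 3 `CC(C(=O)NCc1ccc(C(C)(C)C)cc1SC1CCCCC1)c1ccc(NS(C)(=O)=O)c(F)c1` gives 7.4 nM in an assay on cells for antagonist activity at transient receptor potential cation channel subfamily V member 1 (Homo sapiens), read by FLIPR and calcium flux, with a stated time of 6 min (on this read-out higher numbers stand for weaker inhibition and lower numbers for stronger inhibition), the highest of the three numbers shown, though its neighbours lie close: compound 1 `CCCOc1cc(C(C)(C)C)ccc1CNC(=O)C(C)c1ccc(NS(C)(=O)=O)c(F)c1` gives 4.4 nM and compound 2 `CC(C(=O)NCc1ccc(C(C)(C)C)cc1OCc1ccc(F)cc1)c1ccc(NS(C)(=O)=O)c(F)c1` gives 3.8 nM. The steps of a 1.7-fold higher number from compound 1 to compound 3 (0.23 log units; within the scatter) and a 1.9-fold higher number from compound 2 to compound 3 (0.29 log units; within the scatter) both sit within the scatter, as does a 1.2-fold lower number from compound 1 to compound 2 (0.06 log units; within the scatter). Compound 4 `C[C@H](C(=O)NCc1ccc(C(C)(C)C)cc1SC1CCCCC1)c1ccc(NS(C)(=O)=O)c(F)c1` keeps every atom and bond of compound 3 and differs only in one respect: the two compounds have the same atoms and bonds; at least one stereo element is drawn with a configuration in one of them and without one in the other: 1 of 1 stereo elements differ; a stereocentre at a saturated chain carbon is drawn without a configuration in compound 3 and S in compound 4. For the measured compounds named here, none of the measured steps touches a stereocentre; each swaps a group on the aromatic ring, so none of them bears directly on this change, and its direction is open. For compound 4 the expected step is a 1.5-fold lower number from compound 3 to compound 4 (0.17 log units; within the scatter). Compound 4 is therefore estimated at 5 nM, with a range from 2 nM to 50 nM.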

Compound 4, inhibition constant: 6 nM
For compound 4 the middle estimate is 1.2-fold (0.08 log units) below the measured one; the range from low to high includes it.
By their numbers in this assay, from the lowest: compounds 2, 1, 4 and 3 (each within the scatter of the next).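

Unlike the earlier steps, which swap groups on the aromatic ring, this one touches the saturated chain carbon, and in this assay it gives a 1.2-fold lower number from compound 3 to compound 4 (0.09 log units; within the scatter). Drawing this centre as S therefore leaves the number within the scatter of the compound drawn without a configuration. All that separates the pair is this: the fact that one of compounds 3 and 4 is drawn with a defined configuration and the other without, at the place where they differ

Open, on these data alone, is how the R form would read, and whether compound 3 contains it, so S cannot be set against its mirror image. Also open, as far as these compounds go, is what a longer chain or an amine on this carbon would do.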